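Adding a second methoxy to compound 3

The source may hold more compounds than are shown below. What is called first, only, known or untested is meant among the compounds shown, and "the series" means these compounds.

In a functional assay on M21 cells (Homo sapiens) for antiproliferative activity, read by sulforhodamine B assay, with a stated time of 48 h (a lower number here means a stronger inhibitor, a higher number a weaker inhibitor), compound 2 (`CCCCN1CCN(c2ccc(S(=O)(=O)Oc3ccccc3OC)cc2)C1=O`) reaches only a limit of the assay, > 100000 nM. Compound 3 (`CCCCN1CCN(c2ccc(S(=O)(=O)Oc3cccc(OC)c3)cc2)C1=O`) gives 30000 nM and compound 1 (`CCN1CCN(c2ccc(S(=O)(=O)Oc3ccc(OC)c(OC)c3)cc2)C1=O`) gives 35000 nM, values within the scatter of each other. Compound 4 (`CCCCN1CCN(c2ccc(S(=O)(=O)Oc3ccc(OC)c(OC)c3)cc2)C1=O`) differs from compound 3 by methoxy in place of hydrogen on an aromatic carbon, turning 3-methoxyphenyl into 3,4-dimethoxyphenyl, with the new methoxy ortho to the existing one. Among the measured compounds shown here, the only measured step, an at least 3.3-fold lower number from compound 2 to compound 3 (0.52 log units; beyond the scatter), concerns a methoxy changing place, not a second one entering, so it bears only loosely. Compound 1, at 35000 nM, already carries 3,4-dimethoxyphenyl, though with ethyl where compound 3 has butyl. The expected result is a 1.2-fold lower number from compound 3 to compound 4 (0.08 log units; within the scatter), nothing beyond the scatter. Compound 4 is estimated at 25000 nM, within a range of 8000 nM to 70000 nM.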

Compound 4, half-maximal inhibitory concentration: > 100000 nM
Compound 4 ended at the assay's limit (the forecaster's own chance of this, stated with the estimate: 10%); at least 4.0-fold (0.60 log units) between middle value and limit.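

In this assay, adding the second methoxy on the butyl compound gives an at least 3.3-fold higher number from compound 3 to compound 4 (0.52 log units; beyond the scatter) and so loses activity, which the move of a single methoxy could not show. With 3,4-dimethoxyphenyl held fixed, the chain also counts: there is an at least 2.8-fold higher number from compound 1 to compound 4 (0.45 log units; beyond the scatter) as ethyl gives way to butyl. Compound 2 and compound 4 both sit at a limit, so the step joining them cannot be read: the limit of > 100000 nM in this assay, at which 2 of the 4 values shown sit.

Still open, going by these compounds, is whether a hydroxyl or an amine in place of the new methoxy would keep a readable value. Also open, on these data alone, is how a propyl chain would behave with 3,4-dimethoxyphenyl.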